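The source may report more compounds than this note shows. Statements on the series, on what has been measured and on what is new or still open speak of the compounds shown alone.

Measured compounds:
compound 1, `ClCc1ccc(Cn2cnc3c(Cl)ncnc32)cc1`, gives > 100000 nM in a functional assay on MOLT-4 cells (Homo sapiens) for cytotoxicity, read by sulforhodamine B assay, with a stated time of 48 h; on this read-out lower numbers stand for stronger inhibition of growth and higher numbers for weaker inhibition of growth;
compound 2, `ClCc1cccc(Cn2cnc3c(Cl)ncnc32)c1`, gives 37200 nM in this assay;
compound 3, `ClCc1ccccc1Cn1cnc2ncnc(Cl)c21`, gives 4260 nM in this assay.

The value for compound 1 is only a limit of this assay, not a measured number, as shown by the limit of > 100000 nM in this assay, at which 1 of the 3 values shown sits. Compound 2 and compound 3 each give a number, and both sit at lower concentrations than the limit at which compound 1 stands; of the three, compound 1 is the one with no number at all, so it stands at the weak end of what is shown.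

Compound 4, `ClCc1ccc(Cn2cnc3c(Cl)nc(Cl)nc32)cc1`, is not yet measured. It differs from compound 1 in one place: chloro in place of hydrogen on an aromatic carbon. The new chloro sits on the ring that already carries a chloro group, between two ring nitrogen atoms, as the structure shows.

Among the compounds with values here, no pair of compounds differing only at this position has been measured, so the size and direction of the step are unknown from these data. Since compound 1 sits at the limit > 100000 nM, a step in either direction is possible. The expectation for compound 4 is 70000 nM, within 15000 nM to 300000 nM. This estimate corresponds to a step of an at least 1.4-fold lower number from compound 1 to compound 4 (0.15 log units; that floor lies within the scatter), expected to be modest and with a real chance that only a limit is again reported.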

Compound 4, concentration for total growth inhibition: 27500 nM
For compound 4 the middle estimate is 2.5-fold (0.41 log units) above the measured one; measured number inside the range.
By their numbers in this assay, from the lowest: compound 3; then compounds 4 and 2 (each within the scatter of the next). At a limit, above all of these: compound 1.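

Chloro in place of hydrogen on this aromatic carbon, between two ring nitrogen atoms, gives the first step that can be read at this position: in this assay, the change gives an at least 3.6-fold lower number from compound 1 to compound 4 (0.56 log units; beyond the scatter). The earlier compounds shown here could not show this, as none of them differed from another in one place only, and now a single added chlorine atom is seen to matter here, turning a limit into a measured number. The step can be stated only as a floor, not as a full size, because compound 1 stands only at a limit of the assay: the limit of > 100000 nM in this assay, at which 1 of the 4 values shown sits.

Going by these compounds, whether other groups at this position, such as an amine, a methoxy group or a longer chain, would move the number in the same direction or by a similar amount remains open. Also open is whether the same chloro change would give a similar step on compound 2 or compound 3, and the numbers shown do not say why the added chloro has this effect.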